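Trimming the hydroxyalkyl chain on the amine nitrogen

A few compounds are considered here, and "the series" means these few. Any claim that something is new, unique, unknown or untested is made for them only; others in the source may bear on it.

Compound 1 `COCCCNC(=C\C(=O)/C=C/c1ccc(O)cc1)/C=C/c1ccc(O)cc1` and compound 2 `O=C(/C=C(/C=C/c1ccc(O)cc1)NCCCO)/C=C/c1ccc(O)cc1` differ only in that compound 2 carries hydrogen in place of methyl on an oxygen on a saturated carbon. In a functional assay on Caco-2 cells (Homo sapiens) for cytotoxicity, read by MTT assay, with a stated time of 48 h (a lower number here means a stronger inhibitor, a higher number a weaker inhibitor), compound 1 gives 24000 nM and compound 2 gives 31600 nM, so compound 2 stands highest of the two numbers, with compound 1 nearest; the step of a 1.3-fold higher number from compound 1 to compound 2 (0.12 log units; within the scatter) lies within the scatter. Compound 3 `O=C(/C=C(/C=C/c1ccc(O)cc1)NCCO)/C=C/c1ccc(O)cc1` is the next change: hydroxy in place of hydroxymethyl on a saturated chain carbon, two bonds along the chain from an amine nitrogen. Among the measured compounds shown here, the one measured step also altered this tail and barely moved the number, so no shift beyond the scatter is expected. Compound 3 is expected at 30000 nM, within 12000 nM to 80000 nM. The expected step is a 1.1-fold lower number from compound 2 to compound 3 (0.02 log units; within the scatter).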

Compound 3, half-maximal inhibitory concentration in the Caco-2 assay: 57900 nM
Beside the measured number, compound 3's estimate is 1.9-fold (0.29 log units) below it; measured number inside the range.
By their numbers in the Caco-2 assay, from the lowest: compounds 1, 2 and 3 (each within the scatter of the next, the first and the last beyond it).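

Hydroxy in place of hydroxymethyl gives, in the Caco-2 assay, a 1.8-fold higher number from compound 2 to compound 3 (0.26 log units; within the scatter), so this single trim stays inside the scatter. Hydroxy in place of methoxymethyl gives a 2.4-fold higher number from compound 1 to compound 3 (0.38 log units; beyond the scatter), the first step in this set to pass the scatter, towards weaker inhibition. In a physicochemical assay for solubility, using the shake flask method, in phosphate buffer, with a stated time of 90 min, at pH 6.8 (on this read-out higher numbers stand for higher solubility and lower numbers for lower solubility), compound 2 gives 137000 nM and compound 3 gives 38700 nM, so the shorter 2-hydroxyethyl chain clearly costs solubility: the measured solubility of compound 2, 137000 nM, and of compound 3, 38700 nM, a 3.5-fold lower number (0.55 log units; beyond the scatter)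

Still open, on these data alone, is whether a longer chain, or an amine in place of the terminal hydroxy, would shift either number.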